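A few compounds are considered here, and "the series" means these few. Any claim that something is new, unique, unknown or untested is made for them only; others in the source may bear on it.

Compound 3 `CC1CCN(C(=O)N2CC(c3nc(-c4cccc(Cl)c4)no3)C2)CC1` is inactive in an assay on HEK293 cells for negative allosteric modulation of metabotropic glutamate receptor 5 (Homo sapiens), read by FLIPR (a lower number here means a stronger inhibitor, a higher number a weaker inhibitor), up to the tested ceiling: in this assay compound 3 gives > 10000 nM, which is a limit and not a number. Compound 1 `CC1CCCC(C(=O)N2CC(c3nc(-c4cccc(Cl)c4)no3)C2)C1` likewise returns only the limit > 10000 nM in this assay. Compound 2 `O=C(N1CCCCC1)N1CC(c2nc(-c3cccc(Cl)c3)no2)C1` also returns only the limit > 10000 nM in this assay. All three sit together, as the limit of > 10000 nM in this assay, at which 3 of the 3 values shown sit, records. Compound 4 `COC1CCCN(C(=O)N2CC(c3nc(-c4cccc(Cl)c4)no3)C2)C1` differs from compound 3 by 3-methoxypiperidin-1-yl in place of 4-methylpiperidin-1-yl on a carbonyl carbon. The measured steps a step that the two limits leave unreadable from compound 1 to compound 2, a step that the two limits leave unreadable from compound 1 to compound 3 and a step that the two limits leave unreadable from compound 2 to compound 3 are all unreadable, so they offer no direction for the new change. The expected step that the limit leaves unreadable from compound 3 to compound 4 is therefore none beyond the scatter. Compound 4 is expected to give 15000 nM in this assay, most probably again as a limit, with a range of 4000 nM to 50000 nM.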

Compound 4, half-maximal inhibitory concentration: 1830 nM
For compound 4 the middle estimate is 8.2-fold (0.91 log units) above the measured one, and the stated range ends above it.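

In this assay, the group on the carbonyl carbon now gives a readable value, and 3-methoxypiperidin-1-yl in place of 4-methylpiperidin-1-yl gives an at least 5.4-fold lower number from compound 3 to compound 4 (0.73 log units; beyond the scatter). Adding a methoxy to piperidin-1-yl gives an at least 5.4-fold lower number from compound 2 to compound 4 (0.73 log units; beyond the scatter), and 3-methoxypiperidin-1-yl in place of 3-methylcyclohexyl gives an at least 5.4-fold lower number from compound 1 to compound 4 (0.73 log units; beyond the scatter). These sizes are bounds, the steps among compound 1, compound 2 and compound 3 cannot be read, and the other compounds stay at the ceiling: the limit of > 10000 nM in this assay, at which 3 of the 4 values shown sit.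

Still open, going by these compounds, is whether the methoxy itself or its ring position carries the step. 3-Methylpiperidin-1-yl, 4-methoxypiperidin-1-yl and 3-hydroxypiperidin-1-yl on the carbonyl carbon would separate these.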